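The source may hold more compounds than are shown below. What is called first, only, known or untested is meant among the compounds shown, and "the series" means these compounds.

Measured so far:
Compound 1, `COC(=O)c1ccc(C(=O)Nc2cccc(NC(=O)COc3ccc4c(=O)ccoc4c3)c2)cc1`: in an assay on isolated protein for inhibition of Rho-associated protein kinase 2 (Homo sapiens), read by scintillation counting, radiometric assay and 33P incorporation, with a stated time of 40 min, in the presence of a further agent that is not named here (a higher number here means a weaker inhibitor, a lower number a stronger inhibitor), compound 1 gives 29 nM.
Compound 2, `O=C(COc1ccc2c(=O)ccoc2c1)Nc1cccc(NC(=O)c2cccc([N+](=O)[O-])c2)c1`: in this assay compound 2 gives 41 nM.

Compound 2 holds the higher of these two numbers, but the step of a 1.4-fold higher number from compound 1 to compound 2 (0.15 log units; within the scatter) lies within the scatter, so no order between the two can be read from it. Compound 3, `Cc1cc(C(=O)Nc2cccc(NC(=O)COc3ccc4c(=O)ccoc4c3)c2)ccc1C(F)(F)F`, has not yet been measured. Its change from compound 2 is a group of 11 heavy atoms (8 carbon, 3 fluorine; one six-membered aromatic ring of carbon only) in place of a group of 9 heavy atoms (6 carbon, 1 nitrogen, 2 oxygen; one six-membered aromatic ring of carbon only), on a carbonyl carbon. Among the measured compounds shown here, the only measured step that bears on it is the earlier exchange of the aryl group on that same carbonyl carbon, a 1.4-fold higher number from compound 1 to compound 2 (0.15 log units; within the scatter), which stayed within the scatter. On that basis a further exchange at this position is expected to move the number in this assay little, if at all, in either direction. Compound 3 is therefore estimated at 40 nM, with a range from 15 nM to 110 nM. This corresponds to an expected step of a 1.0-fold lower number from compound 2 to compound 3 (0.01 log units; within the scatter).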

Compound 3, half-maximal inhibitory concentration: 43 nM
Estimate against measurement, compound 3: 1.1-fold (0.03 log units) below, and the stated range covers the measured number.
By their numbers in this assay, from the lowest: compounds 1, 2 and 3 (each within the scatter of the next).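

In this assay the carbonyl carbon whose other neighbour is an amide-type nitrogen has now carried three different aryl groups, and the steps among them stay within the scatter (a 1.0-fold higher number from compound 2 to compound 3 (0.02 log units; within the scatter); a 1.5-fold higher number from compound 1 to compound 3 (0.17 log units; within the scatter)). The first of these steps is the more informative: 3-nitrophenyl, with 2 hydrogen-bond acceptors, gives way to a group with 0 hydrogen-bond acceptors, and fluorine enters, yet no change in the number can be read. Nothing measured here accounts for this result.

Each group shown at this place holds a six-membered aromatic ring of carbon only, so it remains open whether a saturated ring or a longer chain would keep the number in this range. On these data alone, the effect of an amine or a carboxylic acid on that ring also remains open.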